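Lengthening the link from the core to a phenyl ring

The source may report more compounds than this note shows. Statements on the series, on what has been measured and on what is new or still open speak of the compounds shown alone.

Compounds measured:
compound 1 `CC(C(=O)NCc1ccc(C(F)(F)F)nc1-c1ccc(F)c(Cl)c1)c1ccc(NS(C)(=O)=O)c(F)c1`, 0.2 nM
compound 2 `CC(C(=O)NCc1ccc(C(F)(F)F)nc1-c1ccco1)c1ccc(NS(C)(=O)=O)c(F)c1`, 5.8 nM
compound 3 `CC(C(=O)NCc1ccc(C(F)(F)F)nc1Cc1ccccc1)c1ccc(NS(C)(=O)=O)c(F)c1`, 141 nM

All three share one core and differ only in the group on one aromatic carbon of that core. In an assay on CHO cells for antagonist activity at transient receptor potential cation channel subfamily V member 1 (Homo sapiens), read by FLIPR (a lower number here means a stronger inhibitor, a higher number a weaker inhibitor), compound 1 gives 0.2 nM, compound 2 gives 5.8 nM, and compound 3 gives 141 nM. Compound 3 has the highest number of the three: the step of a 710-fold higher number from compound 1 to compound 3 (2.85 log units; beyond the scatter) and the step of a 24-fold higher number from compound 2 to compound 3 (1.39 log units; beyond the scatter) are both large, so among these compounds it is the weakest inhibitor.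

Compound 4 `CC(C(=O)NCc1ccc(C(F)(F)F)nc1CCc1ccc(F)cc1)c1ccc(NS(C)(=O)=O)c(F)c1` takes this one bond further: 4-fluorobenzyl in place of phenyl on a saturated chain carbon bound to an aromatic carbon. Among the compounds with values here, none of the measured steps swaps a benzyl for a 2-(4-fluorophenyl)ethyl, so no step bears on it directly. The steps of a 710-fold higher number from compound 1 to compound 3 (2.85 log units; beyond the scatter) and a 24-fold higher number from compound 2 to compound 3 (1.39 log units; beyond the scatter) show only that placing a saturated carbon between the core and the ring, as in compound 3, cost a great deal, which gives no ground for expecting a gain when a second carbon is added. Compound 4 is therefore expected to stay near compound 3 or lose a little: the estimated step is a 1.8-fold higher number from compound 3 to compound 4 (0.25 log units; within the scatter), and the estimate for compound 4 in this assay is 250 nM, within 60 nM to 1000 nM.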

Compound 4, inhibition constant: 1.8 nM
Compound 4: the middle estimate sits 140-fold (2.14 log units) above what was measured, outside the stated range (below it).
By their numbers in this assay, from the lowest: compound 1; then compound 4; then compound 2; then compound 3.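

Lengthening the link changes the picture at this position: a saturated chain does not by itself cost activity in this assay, since 2-(4-fluorophenyl)ethyl recovers almost all that benzyl lost (a 78-fold lower number from compound 3 to compound 4 (1.89 log units; beyond the scatter)). This chain also outdoes furan-2-yl (a 3.2-fold lower number from compound 2 to compound 4 (0.51 log units; beyond the scatter)), though it still falls short of 3-chloro-4-fluorophenyl attached directly to the core (a 9.0-fold higher number from compound 1 to compound 4 (0.95 log units; beyond the scatter)). No evidence is available on why the longer chain gives this gain.

The step from compound 3 to compound 4 adds a chain carbon and a fluorine together, so these compounds cannot separate the two, whereas the plain 2-phenylethyl group could. Going by these compounds, how a still longer chain, such as 3-(4-fluorophenyl)propyl, or an amine in the link would fare also stays open.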